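Replacing a cycloalkyl amine with an aryl amine on a shared core

This account rests on a few compounds, and the source may have more. Where it says the series, first, only, none or still open, it means among the compounds named here.

Compound 1, `O=C1C(NC2CCCC2)=CC(=O)c2c1nc1n2[C@H]2OC[C@@H](O)[C@H]2OC1`, gives only a limit of > 16000 nM in a functional assay on HeLa cells (Homo sapiens) for inhibition, read by sulforhodamine B assay; a higher number here means a weaker inhibitor, a lower number a stronger inhibitor; this is a limit of the assay, not a number.
Compound 2, `O=C1C=C(NC2CCCCC2)C(=O)c2c1nc1n2[C@H]2OC[C@@H](O)[C@H]2OC1`, likewise gives only a limit of > 16000 nM in this assay.
Compound 3, `CCOc1ccc(NC2=CC(=O)c3nc4n(c3C2=O)[C@H]2OC[C@@H](O)[C@H]2OC4)cc1`, gives 3110 nM in this assay.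

Compound 1 therefore stands at the top of the range that this assay can report, the position described by the limit of > 16000 nM in this assay, at which 2 of the 3 values shown sit, and no number for it is known. Compound 4, `CCCc1ccc(NC2=CC(=O)c3c(nc4n3[C@H]3OC[C@@H](O)[C@H]3OC4)C2=O)cc1`, has not yet been measured. It differs from compound 1 in one place: 4-propylphenyl in place of cyclopentyl on an amine nitrogen.

One measured step speaks to this change. Between compound 2 and compound 3 an aromatic ring took the place of a saturated ring on the same amine nitrogen, and the result was an at least 5.1-fold lower number from compound 2 to compound 3 (0.71 log units; beyond the scatter). The change from compound 1 to compound 4 is of the same kind, a saturated ring giving way to a substituted phenyl on the amine nitrogen, so a step of similar size and in the same direction is expected, meaning a lower number for compound 4 than the limit recorded for compound 1.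

Compound 4 is therefore estimated at 4000 nM in this assay, within a range of 1500 nM to 12000 nM, which corresponds to an expected at least 4.0-fold lower number from compound 1 to compound 4 (0.60 log units; beyond the scatter).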

Compound 4, half-maximal inhibitory concentration: 6030 nM
For compound 4 the middle estimate is 1.5-fold (0.18 log units) below the measured one; the measured number falls inside the stated range.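

The new step shows that the swap of a saturated ring for a substituted phenyl on the amine nitrogen also pays off in a second pair of compounds, with a different saturated ring leaving and a different phenyl group entering: an at least 2.6-fold lower number from compound 1 to compound 4 (0.42 log units; beyond the scatter). Until now, this kind of change rested on a single pair, so compound 4 makes it a small pattern of two steps in this assay, and no compound shown goes against it. The true size of the step stays unknown because compound 1 has only a limit and not a number, as do most of the saturated-ring compounds shown: the limit of > 16000 nM in this assay, at which 2 of the 4 values shown sit.

As far as these compounds go, what remains open is whether the aromatic ring alone carries the change or whether its 4-propyl group contributes, which a plain phenyl on the same amine nitrogen would help to separate. From the compounds shown here alone, it is also open how a chain at that spot compares with other groups on the ring, such as a hydroxyl, an amine or a carboxylic acid.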